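This account rests on a few compounds, and the source may have more. Where it says the series, first, only, none or still open, it means among the compounds named here.

In an ADME assay on microsomes from liver (Mus musculus) for metabolic stability, with a stated time of 10 min (a lower number here means that less of the compound is left, a higher number that more of the compound is left), compound 3 (`O=C(N[C@H]1CC[C@@H](c2ccccc2)CC1)c1[nH]c(=O)[nH]c(=O)c1O`) gives 100% in this test. Compound 1 (`CCN1CC(C(=O)NC(C)CCc2ccc(Cl)c(Cl)c2)=C(O)C1=O`) gives 92% here, which lies within the usual scatter of compound 3, so these two numbers cannot be told apart. Compound 2 (`Nc1c(C(=O)N[C@H]2CC[C@@H](c3ccc(OCc4ccccc4)cc3)CC2)[nH]c(=O)[nH]c1=O`) gives 85% here, a gap to compound 3 that lies beyond the scatter, although compound 1 and compound 2 stand within the scatter of each other.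

Compound 4 (`O=C(N[C@H]1CC[C@@H](c2ccccc2)CC1)c1[nH]c(=O)n(Cc2ccccc2)c(=O)c1O`) has not been measured yet. It is compound 3 with a single change, benzyl in place of hydrogen on an aromatic nitrogen here, which means benzyl in place of hydrogen on an aromatic nitrogen.

Going by the values given here, no measured pair shows this change on its own, so the data offer only a weak guide. Among the compounds with values here, the one hint is compound 2, which also carries a benzyl group, though elsewhere in the molecule, and gives 85% in this assay as its result. A moderate fall in the amount left is therefore expected, and the estimated step is a number 18 percentage points lower from compound 3 to compound 4 (beyond the scatter) in this test, probably somewhat beyond the scatter. Compound 4 is estimated at 82% here, with an expected range from 62% to 97% in this test.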

Compound 4, percent of the compound remaining: 0.78%
The estimate for compound 4 lay 81.2 percentage points above the measured number; measured number outside the range, below it.
By their numbers in this assay, from the lowest: compound 4; then compounds 2, 1 and 3 (each within the scatter of the next, the first and the last beyond it).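

In this assay, going by these compounds alone, the single change of benzyl in place of hydrogen on an aromatic nitrogen gives a number 99.2 percentage points lower from compound 3 to compound 4 (beyond the scatter), a large step that turns a compound that stays almost entirely intact into one of which almost nothing is left. The earlier compounds shown here offered no pair that differed at this position, para to a large group on the ring, so only now is it clear that a change at this one nitrogen can decide how much of the compound survives the test. Within the data shown here, nothing measured so far speaks to the reason for this drop.

The compounds shown leave open whether the drop belongs to benzyl in particular or would follow from any group on this nitrogen, and a small methyl group, a plain phenyl group or a longer chain ending in a carboxylic acid at the same place would help separate these possibilities. They also leave open whether the same benzyl group would have so large an effect on a different core, such as that of compound 1.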